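This account rests on a few compounds, and the source may have more. Where it says the series, first, only, none or still open, it means among the compounds named here.

Measured in a functional assay on RAW264.7 cells (Mus musculus) for inhibition, read by Griess assay, with stated times of 1 h and 24 h; on this read-out higher numbers stand for weaker inhibition and lower numbers for stronger inhibition:
compound 1 `CC(C)=CCOc1ccccc1C1CC(=O)c2ccccc2O1` gives 32700 nM
compound 2 `O=C1CC(c2ccccc2OCc2ccccc2)Oc2ccccc21` gives 18900 nM
compound 3 `O=C1CC(c2ccccc2O)Oc2ccccc21` gives 71300 nM

Compound 3 has the highest number of the three, which makes it the weakest inhibitor here. Compound 4 `O=C1CC(c2ccccc2OCc2cccc(F)c2)Oc2ccccc21` comes from it by one change, 3-fluorobenzyl in place of hydrogen on an oxygen on an aromatic ring. Among the measured compounds shown here, two measured steps bear on this: a 3.8-fold higher number from compound 2 to compound 3 (0.58 log units; beyond the scatter) and a 2.2-fold higher number from compound 1 to compound 3 (0.34 log units; beyond the scatter). Each takes a group off that oxygen, so read backwards, adding a group lowered the number both times. Comparing those two groups directly gives a 1.7-fold lower number from compound 1 to compound 2 (0.24 log units; within the scatter). For the measured compounds named here, no measured compound carries the fluorine, so compound 2 is the closest guide. The expected change is a modest drop, a 3.6-fold lower number from compound 3 to compound 4 (0.55 log units; beyond the scatter). For compound 4 the estimated value is 20000 nM, with an expected range from 9000 nM to 45000 nM.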

Compound 4, half-maximal inhibitory concentration: 15600 nM
Compound 4: middle estimate off by 1.3-fold (0.11 log units), on the high side; the measured number falls inside the stated range.
By their numbers in this assay, from the lowest: compounds 4, 2 and 1 (each within the scatter of the next, the first and the last beyond it); then compound 3.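

Adding 3-fluorobenzyl on this oxygen gives a 4.6-fold lower number from compound 3 to compound 4 (0.66 log units; beyond the scatter), so the drop seen with the earlier groups also holds for a benzyl group carrying fluorine. The fluorine itself makes no distinguishable difference, with a 1.2-fold lower number from compound 2 to compound 4 (0.08 log units; within the scatter), yet compound 4 clears the scatter against the prenyl-type ether, with a 2.1-fold lower number from compound 1 to compound 4 (0.32 log units; beyond the scatter), which the unfluorinated benzyl of compound 2 did not. No evidence available here accounts for these steps. On these data alone, whether a chloro or methoxy group in place of the fluorine, or a chain ending in an amine or a carboxylic acid in place of the benzyl, would lower the number further remains open.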